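This account rests on a few compounds, and the source may have more. Where it says the series, first, only, none or still open, it means among the compounds named here.

Measured compounds:
- compound 1 `C=C1CCC(c2csc(/C=C(\C)C(N)=O)c2)CC1` gives 18000 nM
- compound 2 `C/C(=C\c1cc(-c2ccc(C#N)cc2)cs1)C(N)=O` gives 130 nM

Both numbers come from a functional assay on HO8910 cells (Homo sapiens) for cytotoxicity, read by CCK-8 assay, with a stated time of 24 h; on this read-out higher numbers stand for weaker inhibition and lower numbers for stronger inhibition. Among the two measured compounds, compound 2 has the lowest number, and the gap to compound 1 lies well beyond the usual scatter of repeated measurements, so on this read-out compound 2 is clearly the stronger inhibitor of the pair.

The next compound, compound 3 `C=Cc1ccc(-c2csc(/C=C(\C)C(N)=O)c2)cc1`, differs from compound 2 in a single place: vinyl in place of cyano on an aromatic carbon. Within the data shown here, no measured pair of compounds shows this particular exchange, so there is no direct precedent in these data for how large the resulting step might be. Both the group that leaves and the group that enters are small and sit in the same position, which suggests a modest step rather than a large one. The expected step in this assay is small and, if anything, slightly upward, that is, toward weaker inhibition, with a real chance of no change beyond the scatter. The step expected from this exchange is a 1.9-fold higher number from compound 2 to compound 3 (0.28 log units; within the scatter). Compound 3 is therefore estimated to give about 250 nM, with a plausible range from 60 nM to 1200 nM.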

Compound 3, half-maximal inhibitory concentration: > 50000 nM
Compound 3 gave a limit, no number; the forecaster's own chance of this, stated with the estimate: 5%; middle value at least 200-fold (2.30 log units) from the limit.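

The reading of compound 3 in this assay is a limit and not a number: the limit of > 50000 nM in this assay, at which 1 of the 3 values shown sits. Even so, putting vinyl in place of cyano, on an aromatic carbon of the six-membered ring and para to a large group, gives an at least 380-fold higher number from compound 2 to compound 3 (2.58 log units; beyond the scatter), so what sits at this position matters greatly on this read-out. Both groups have 2 heavy atoms and neither contains a ring, so matching those counts is clearly not enough to keep the activity of compound 2, although cyano brings a nitrogen and a hydrogen-bond acceptor that vinyl lacks, and this single pair cannot tell whether that difference is what counts.

On these data alone, it remains open whether an amine, a methoxy group or a chlorine atom at the same carbon would stay close to compound 2 or fall away as compound 3 does. An ethyl group or a carboxylic acid there would also help show whether the loss follows the carbon-only make-up of vinyl or something else about it.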